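A few compounds are considered here, and "the series" means these few. Any claim that something is new, unique, unknown or untested is made for them only; others in the source may bear on it.

Compound 1 (`CCCCCCCCCCCCCCNC(=O)[C@H](CO)/N=C/c1ccccc1Cl`) gives 94900 nM in an ADME assay on HEK293 cells (Homo sapiens) for cytotoxicity; a higher number here means a weaker inhibitor, a lower number a stronger inhibitor
Compound 2 (`CCCCCCCCCCCCCCNC(=O)[C@H](CO)/N=C/c1ccccc1O`) gives 80800 nM
Compound 3 (`CCCCCCCCCCCCCCNC(=O)[C@H](CO)/N=C/c1ccc([N+](=O)[O-])cc1`) gives 49500 nM

The steps of a 1.9-fold lower number from compound 1 to compound 3 (0.28 log units; within the scatter) and a 1.6-fold lower number from compound 2 to compound 3 (0.21 log units; within the scatter) leave compound 3 not set apart from the other two. Compound 4 (`CCCCCCCCCCCCCCNC(=O)[C@H](CO)/N=C/c1cccc(O)c1`) differs from compound 3 by 3-hydroxyphenyl in place of 4-nitrophenyl on a carbon with a double bond to nitrogen. Among the measured compounds shown here, no measured compound carries 3-hydroxyphenyl. The closest guide is compound 2 with its 2-hydroxyphenyl, and the step of a 1.6-fold lower number from compound 2 to compound 3 (0.21 log units; within the scatter) is small. The hydroxy-for-chloro step a 1.2-fold lower number from compound 1 to compound 2 (0.07 log units; within the scatter) is small as well. No step beyond the scatter is therefore expected in this assay, and the number for compound 4 is expected to fall near that of compound 2 (80800 nM). The estimated step is a 1.4-fold higher number from compound 3 to compound 4 (0.15 log units; within the scatter) and it is expected to stay small. Compound 4 is estimated at 70000 nM (expected range 40000 nM to 120000 nM).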

Compound 4, half-maximal inhibitory concentration: 77500 nM
The estimate for compound 4 lay 1.1-fold (0.04 log units) below the measured number; measured number inside the range.
By their numbers in this assay, from the lowest: compounds 3, 4, 2 and 1 (each within the scatter of the next).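

In this assay, 3-hydroxyphenyl in place of 2-hydroxyphenyl on a carbon with a double bond to nitrogen gives a 1.0-fold lower number from compound 2 to compound 4 (0.02 log units; within the scatter), so this assay does not tell the two hydroxyphenyl groups apart at this place. The exchanges from the other two groups also stay within the scatter, with 3-hydroxyphenyl in place of 4-nitrophenyl giving a 1.6-fold higher number from compound 3 to compound 4 (0.19 log units; within the scatter) and in place of 2-chlorophenyl giving a 1.2-fold lower number from compound 1 to compound 4 (0.09 log units; within the scatter), so none of the four aromatic groups shown is set apart from the others. Nothing available here accounts for this lack of separation.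

The compounds shown leave open whether an amine or a carboxylic acid on the phenyl ring would give a step beyond the scatter. They also leave open what a shorter chain on the shared core would do to the number in this assay.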